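Urea on the pyrrolidine of a melanin-concentrating hormone receptor 1 ligand

The source may hold more compounds than are shown below. What is called first, only, known or untested is meant among the compounds shown, and "the series" means these compounds.

Compound 1 `CN(c1ccc2cc(NC(=O)CCc3ccc(C(F)(F)F)cc3)ccc2n1)C1CCCC1`: 2 nM
Compound 2 `CC1CCN(c2ccc3cc(NC(=O)CCc4ccc(C(F)(F)F)cc4)ccc3n2)C1`: 2 nM

In an assay on isolated protein for displacement of a labelled ligand from melanin-concentrating hormone receptor 1 (Homo sapiens) (a lower number here means a stronger inhibitor, a higher number a weaker inhibitor), compound 2 gives 2 nM, level with compound 1 within the scatter, as the step of no change at the digits printed from compound 1 to compound 2 (within the scatter) shows. Compound 3 `CNC(=O)NC1CCN(c2ccc3cc(NC(=O)CCc4ccc(C(F)(F)F)cc4)ccc3n2)C1` carries the change ((methylcarbamoyl)amino in place of methyl on a saturated ring carbon). Going by the values given here, no measured step covers this change; the one known step, no change at the digits printed from compound 1 to compound 2 (within the scatter), shows only that the amine part of the shared core tolerates variation. With nothing else to go on, compound 3 is expected to stay near compound 2, with a modest loss as the more likely direction, a step of a 2.5-fold higher number from compound 2 to compound 3 (0.40 log units; beyond the scatter). The estimate for compound 3 in this assay is 5 nM, in the range 1.5 nM to 20 nM.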

Compound 3, half-maximal inhibitory concentration: 6 nM
Estimate against measurement, compound 3: 1.2-fold (0.08 log units) below; low and high end bracket the measured number.
By their numbers in this assay, from the lowest: compounds 1 and 2 (each within the scatter of the next); then compound 3.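

In this assay, going by these compounds alone, the ring carbon two ring bonds from the ring nitrogen takes a far larger group than methyl, and the number moves beyond the scatter for the first time, yet only modestly (a 3.0-fold higher number from compound 2 to compound 3 (0.48 log units; beyond the scatter)). The same size of step separates the 3-((methylcarbamoyl)amino)pyrrolidin-1-yl compound from the cyclopentyl(methyl)amino parent (a 3.0-fold higher number from compound 1 to compound 3 (0.48 log units; beyond the scatter)). Nothing measured here accounts for this shift.

The compounds shown leave open whether the loss follows the (methylcarbamoyl)amino group itself or any group of that size. A free amine, an acetamide or a carboxylic acid on this ring carbon would begin to separate these readings.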